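Replacing trifluoromethyl with an aminocyclohexanol on the pendant ring

This account rests on a few compounds, and the source may have more. Where it says the series, first, only, none or still open, it means among the compounds named here.

Among the compounds with values here, compound 2 `FC(F)(F)c1cccc(CNc2cc(C(F)(F)F)cc3[nH]ncc23)c1` is the one compound with a number in an assay for inhibition of Tryptophan 2,3-dioxygenase (Homo sapiens), with stated times of 10 min and 60 min; a higher number here means a weaker inhibitor, a lower number a stronger inhibitor: compound 2 gives 12200 nM. Compound 1 `O=C(O)CNc1cccc(CNc2cc(C(F)(F)F)cc3[nH]ncc23)c1` is the other member of the pair, and in this assay compound 1 returns only a limit, > 100000 nM. Within the data shown here, the single measured step, an at least 8.1-fold lower number from compound 1 to compound 2 (0.91 log units; beyond the scatter), is therefore bounded on one side by the limit of > 100000 nM in this assay, at which 1 of the 2 values shown sits. Compound 3 `OC1CCCC(Nc2cccc(CNc3cc(C(F)(F)F)cc4[nH]ncc34)c2)C1` carries (3-hydroxycyclohexyl)amino in place of trifluoromethyl on an aromatic carbon. The step from compound 2 to compound 3 runs opposite to the measured one: an amino-linked group enters where trifluoromethyl sat, the same kind of exchange that separates compound 2 from compound 1, though the incoming group has no net charge. The measured step bears on it in direction only, its size being a limit, so a modest weakening is expected, a 3.3-fold higher number from compound 2 to compound 3 (0.52 log units; beyond the scatter). Compound 3 is expected at 40000 nM, within 10000 nM to 150000 nM, with a real chance that only a limit is returned.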

Compound 3, half-maximal inhibitory concentration: > 100000 nM
Compound 3: a limit, no number; the forecaster's own chance of this, stated with the estimate: 35%; middle value at least 2.5-fold (0.39 log units) from the limit.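

In this assay, (3-hydroxycyclohexyl)amino in place of trifluoromethyl on this aromatic carbon gives an at least 8.1-fold higher number from compound 2 to compound 3 (0.91 log units; beyond the scatter). The incoming group has no net charge and no carboxylic acid, so the loss at this position is not tied to the carboxylic acid of compound 1; both amino-linked groups shown end at a limit, and compound 2, with trifluoromethyl, is the only one of the three with a number. The step between compound 1 and compound 3 cannot be read, and the step to compound 3 from compound 2 is bounded on one side only: the limit of > 100000 nM in this assay, at which 2 of the 3 values shown sit.

Going by these compounds, whether a plain amine, a methoxy or a chlorine on this carbon gives a number remains open. So does the effect of a cyclohexyl ring without the hydroxyl, or of a cyclohexyl joined without the linking nitrogen.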